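The source may report more compounds than this note shows. Statements on the series, on what has been measured and on what is new or still open speak of the compounds shown alone.

Three compounds built on one shared core were tested in a functional assay on C6 cells (Rattus norvegicus) for cytotoxicity, read by MTT assay, with a stated time of 24 h, tested at 12 ug/mL; on this read-out lower numbers stand for a stronger effect and higher numbers for a weaker effect at the one concentration tested. Compound 1 `Cc1ccc(-c2cs/c(=N/NC(=O)CSc3nnnn3-c3ccccc3)n2-c2ccccc2)cc1` gives 55.1% in this assay. Compound 2 `O=C(CSc1ncccn1)N/N=c1/scc(-c2ccc(F)cc2)n1-c1ccccc1` gives 77.4% in this assay, and compound 3 `COc1ccc(-c2cs/c(=N/NC(=O)CSc3ncccn3)n2-c2ccccc2)cc1` gives 78.4%. Among these three numbers compound 3 stands highest; its gap to compound 2 lies within the usual scatter, while its gap to compound 1 lies beyond it. Within the data shown here, the one measured step between close neighbours, a number 1 percentage points higher from compound 2 to compound 3 (within the scatter), shows that exchanging one small group on an aromatic carbon left the read-out essentially unchanged.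

Compound 4 `Cc1ccc(-c2cs/c(=N/NC(=O)CSc3ncccn3)n2-c2ccccc2)cc1` has not yet been measured. It differs from compound 3 in a single place: methyl in place of methoxy on an aromatic carbon. Among the measured compounds shown here, this change sits on an aromatic carbon, as did the step from compound 2 to compound 3, which is the only measured step that bears on it, and that step was small. Compound 1 also carries a methyl in this place but differs from compound 4 elsewhere in the chain, so its lower value is only a loose guide. Compound 4 is therefore expected to give about 74%, with a range from 58% to 88%. That estimate means a step of a number 4.4 percentage points lower from compound 3 to compound 4 (within the scatter), expected to stay within the scatter.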

Compound 4, a percentage reported as activity, at one concentration (the size of the read-out at that concentration, not a potency): 83%
For compound 4 the middle estimate is 9 percentage points below the measured one; measured number inside the range.
By their numbers in this assay, from the lowest: compound 1; then compounds 2, 3 and 4 (each within the scatter of the next).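

In this assay, methyl, methoxy and fluoro on this aromatic carbon, para to a large group, cannot be told apart: the 4-methoxyphenyl to 4-methylphenyl change gives a number 4.6 percentage points higher from compound 3 to compound 4 (within the scatter), and methyl in place of fluoro gives a number 5.6 percentage points higher from compound 2 to compound 4 (within the scatter), so this place has now tolerated three different small groups with no change beyond the scatter. Among these compounds, the new compound also gives the first comparison in which the methyl group stays fixed and only the group on the sulfur differs, with pyrimidin-2-yl in place of 1-phenyl-1H-tetrazol-5-yl giving a number 27.9 percentage points higher from compound 1 to compound 4 (beyond the scatter), the only step here beyond the scatter, and a higher number stands for a weaker effect. Among these four compounds the read-out therefore follows the group on the sulfur rather than the group on the aromatic carbon, and nothing measured here offers a reason for either result.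

The compounds shown leave open whether an amine, a carboxylic acid or a longer chain on this aromatic carbon would also leave the read-out unchanged. They also leave open whether the 1-phenyl-1H-tetrazol-5-yl group on the sulfur would give a similar gain alongside fluoro or methoxy.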